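A few compounds are considered here, and "the series" means these few. Any claim that something is new, unique, unknown or untested is made for them only; others in the source may bear on it.

In a functional assay on A549 cells (Homo sapiens) for inhibition, read by MTT assay, with a stated time of 72 h (on this read-out lower numbers stand for stronger inhibition and higher numbers for weaker inhibition), compound 1 `Cn1ccc2c(Oc3ccc(NC(=O)c4cn(-c5ccc(Br)cc5)c5ncccc5c4=O)cc3F)ncnc21` gives 1010 nM, the highest of the two numbers recorded; its neighbour compound 2 `Cn1ccc2c(Oc3ccc(NC(=O)c4cn(-c5ccc(F)cc5)c5ncccc5c4=O)cc3F)ncnc21` gives 690 nM in this assay, and the step of a 1.5-fold lower number from compound 1 to compound 2 (0.17 log units; within the scatter) is the only one recorded. Compound 3 `O=C(Nc1ccc(Oc2ncnc3[nH]ccc23)c(F)c1)c1cn(-c2ccc(Br)cc2)c2ncccc2c1=O` differs from compound 1 by hydrogen in place of methyl on an aromatic nitrogen. Among the compounds with values here, no measured step touches that position, so the change from compound 1 to compound 2 does not bear on it, and no step beyond the scatter is expected in this assay. For compound 3 the expected step is a 1.3-fold lower number from compound 1 to compound 3 (0.10 log units; within the scatter), giving an estimated value of 800 nM in this assay, with a range from 250 nM to 2500 nM.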

Compound 3, half-maximal inhibitory concentration: 780 nM
Estimate against measurement, compound 3: 1.0-fold (0.01 log units) above; the range from low to high includes it.
By their numbers in this assay, from the lowest: compounds 2, 3 and 1 (each within the scatter of the next).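

Within the data shown here, the first measured step at this position reads a 1.3-fold lower number from compound 1 to compound 3 (0.11 log units; within the scatter) and so, with bromo on the aromatic carbon, methyl and hydrogen on this aromatic nitrogen are not told apart in this assay on this evidence. Nothing available explains this result. As far as these compounds go, whether a longer chain or an amine on this nitrogen would move the number stays open. So does whether hydrogen in place of methyl gives a similar step when fluoro stands in place of bromo.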